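Replacing the acid side chain of compound 3

The source may report more compounds than this note shows. Statements on the series, on what has been measured and on what is new or still open speak of the compounds shown alone.

In a functional assay on NCI-H441 cells (Homo sapiens) for antiproliferative activity, with a stated time of 24 h (on this read-out higher numbers stand for weaker inhibition and lower numbers for stronger inhibition), compound 1 (`O=C1C(Cc2ccccc2F)CNCC1Cc1ccccc1F`) gives 130000 nM. Compound 2 (`O=C(O)CCC(=O)N1C/C(=C\c2ccccc2F)C(=O)/C(=C/c2ccccc2F)C1`) gives 69000 nM, and compound 3 (`O=C(O)COCC(=O)N1C/C(=C\c2ccccc2F)C(=O)/C(=C/c2ccccc2F)C1`) gives 310000 nM, the highest number of the three and so the weakest inhibition seen here. Compound 4 (`O=C1/C(=C/c2ccccc2F)CN(C(=O)c2ccccc2C(=O)O)C/C1=C\c1ccccc1F`) has not yet been measured. It keeps the shared core of compound 3 and differs in one place: 2-carboxyphenyl in place of (carboxymethoxy)methyl on a carbonyl carbon. Put simply, 2-carboxyphenyl stands in place of (carboxymethoxy)methyl on a carbonyl carbon. Among the compounds with values here, only one measured step touches this same side chain: a 4.5-fold higher number from compound 2 to compound 3 (0.65 log units; beyond the scatter). Within the data shown here, it shows that this assay can respond to a change there, but no measured compound carries an aromatic ring in this chain, so the direction stays uncertain. Among the measured compounds shown here, since compound 3 already sits at 310000 nM, the highest number so far, a move toward lower numbers seems likelier than a further rise. The expected change, of modest size, is a 2.2-fold lower number from compound 3 to compound 4 (0.35 log units; beyond the scatter). For compound 4 the estimated value is 140000 nM, with an expected range from 45000 nM to 400000 nM.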

Compound 4, half-maximal inhibitory concentration: 56000 nM
Compound 4: middle estimate off by 2.5-fold (0.40 log units), on the high side; the measured number falls inside the stated range.
By their numbers in this assay, from the lowest: compounds 4, 2 and 1 (each within the scatter of the next, the first and the last beyond it); then compound 3.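

In this assay, putting an aromatic ring into this side chain gives a 5.5-fold lower number from compound 3 to compound 4 (0.74 log units; beyond the scatter), which shows that 2-carboxyphenyl on this carbonyl carbon is compatible with a lower number than (carboxymethoxy)methyl. Set against the saturated chain of compound 2, the same group gives a 1.2-fold lower number from compound 2 to compound 4 (0.09 log units; within the scatter), within the scatter, and this assay does not separate 2-carboxyphenyl from 2-carboxyethyl. Among these three acid-bearing chains, only the (carboxymethoxy)methyl chain of compound 3 stands apart from the other two. No supporting data are at hand to explain these differences.

Every compound shown with a group on this carbonyl carbon carries a carboxylic acid, and the contribution of that acid remains open. A chain ending in an amine or a methyl ester would address this.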